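Methyl in place of hydrogen on the shared core

The source may hold more compounds than are shown below. What is called first, only, known or untested is meant among the compounds shown, and "the series" means these compounds.

Two compounds of the series have been run in a functional assay on MCF7 cells (Homo sapiens) for cytotoxicity, read by MTT assay, with a stated time of 72 h; a higher number here means a weaker inhibitor, a lower number a stronger inhibitor. Compound 1 `Cc1nnc(SCc2cc(=O)c3cc(Cl)ccc3o2)o1` gives > 25000 nM in this assay, which is a limit of the assay and not a number. Compound 2 `Cc1nnc(SCc2cc(=O)c3ccccc3o2)o1` gives > 25000 nM in this assay, again a limit rather than a number. The step that the two limits leave unreadable from compound 1 to compound 2 therefore cannot be read, since both values sit at the limit of > 25000 nM in this assay, at which 2 of the 2 values shown sit. Compound 2 thus stands at the limit of what the assay reports, with no number to set it against.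

Compound 3 `Cc1ccc2oc(CSc3nnc(C)o3)cc(=O)c2c1` has not yet been measured. It differs from compound 2 by methyl in place of hydrogen on an aromatic carbon. Among the compounds with values here, the only measured step is the one from compound 1 to compound 2, and its size is hidden by the two limits, so no step of known size bears on this change. Compound 2 sits at a limit, so compound 3 is expected to return a limit as well, with an estimated step that the limit leaves unreadable from compound 2 to compound 3 not beyond the scatter. Compound 3 is expected at 30000 nM, in a range from 5000 nM to 150000 nM.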

Compound 3, half-maximal inhibitory concentration: > 25000 nM
Compound 3: no number, only a limit (the forecaster's own chance of this, stated with the estimate: 80%); the middle value does not contradict the limit.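

In this assay compound 3 also gives only a limit, so no step among compound 1, compound 2 and compound 3 can be read, and all three remain unranked: the limit of > 25000 nM in this assay, at which 3 of the 3 values shown sit.

The compounds shown leave open how chloro, hydrogen and methyl on this aromatic carbon compare, and whether any change to the shared core yields a measurable value.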